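The compounds below may be only part of what the source reports. "The series", "measured", "known", "first", "only" and "open" are said of these compounds alone.

Among the compounds with values here, in a functional assay on SW-620 cells (Homo sapiens) for cytotoxicity, read by MTT assay, with a stated time of 72 h (a higher number here means a weaker inhibitor, a lower number a stronger inhibitor), two compounds with a shared core have numbers so far: compound 1 `COc1ccc(/C=C2\CCC/C(=C\c3cccc(Br)c3)C2=O)cc1OC` gives 4200 nM, and compound 2 `COc1ccc(/C=C2\CCC/C(=C\c3cccc(Cl)c3Cl)C2=O)cc1OC` gives 10800 nM. Compound 2 therefore holds the higher of the two numbers, and the gap between them lies beyond the scatter. Compound 3 `COc1ccc(/C=C2\CCC/C(=C\c3ccc(Cl)c(Cl)c3)C2=O)cc1OC` has not yet been measured. It carries 3,4-dichlorophenyl in place of 2,3-dichlorophenyl on a double-bonded chain carbon bound to a double-bonded ring carbon. Within the data shown here, only one measured step bears on this change, a 2.6-fold higher number from compound 1 to compound 2 (0.41 log units; beyond the scatter), which was modest and altered the group at the same place. Among the measured compounds shown here, no measured compound yet carries 3,4-dichlorophenyl, so the direction remains uncertain. With compound 2 at 10800 nM, the higher number of the pair, a modest step to a lower number is expected in this assay, similar in size to the one measured. The estimated step is a 2.2-fold lower number from compound 2 to compound 3 (0.33 log units; beyond the scatter). Compound 3 is expected to give about 5000 nM, with an estimated range of 2200 nM to 11500 nM.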

Compound 3, half-maximal inhibitory concentration: 4000 nM
Estimate against measurement, compound 3: 1.3-fold (0.10 log units) above; the measured number falls inside the stated range.
By their numbers in this assay, from the lowest: compounds 3 and 1 (each within the scatter of the next); then compound 2.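

In this assay, exchanging 2,3-dichlorophenyl for 3,4-dichlorophenyl on a double-bonded chain carbon bound to a double-bonded ring carbon gives a 2.7-fold lower number from compound 2 to compound 3 (0.43 log units; beyond the scatter), so with the same atoms in the group and only their joining altered, the number at this place still moves beyond the scatter. The other new comparison, 3,4-dichlorophenyl in place of 3-bromophenyl, gives a 1.1-fold lower number from compound 1 to compound 3 (0.02 log units; within the scatter), which lies within the scatter, so the higher number of compound 2 goes with the 2,3-dichlorophenyl group in this set and not with a dichlorophenyl group as such. Nothing available here accounts for why the arrangement of the two chlorines changes the number.

On these data alone, all three compounds carry only bromine or chlorine on this phenyl ring, so it remains open whether a methoxy group, an amine or a carboxylic acid there would keep the number in the same range. As far as these compounds go, it is also open whether the gap between the two dichlorophenyl groups would persist if the other half of the shared core were changed, since that half is identical in compound 1, compound 2 and compound 3.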